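Anilino variation on the shared core toward compound 4

This account rests on a few compounds, and the source may have more. Where it says the series, first, only, none or still open, it means among the compounds named here.

Compound 1 `CC(C)c1ccc(-c2nc(SCc3cn(CC(=O)NC(=O)Nc4ccccn4)nn3)nc(Nc3ccc(Cl)cc3)c2C#N)cc1` carries a 4-chlorophenyl on the ring nitrogen of the shared core. Going by the values given here, in a functional assay on ECa-109 cells (Homo sapiens) for inhibition, read by MTT assay, with a stated time of 72 h (on this read-out higher numbers stand for weaker inhibition and lower numbers for stronger inhibition), compound 1 gives 11200 nM, the highest of the three numbers measured so far. Compound 2 `COc1ccc(Nc2nc(SCc3cn(CC(=O)NC(=O)Nc4ccccn4)nn3)nc(-c3ccc(C(C)C)cc3)c2C#N)cc1` gives 5420 nM and compound 3 `Cc1ccccc1Nc1nc(SCc2cn(CC(=O)NC(=O)Nc3ccccn3)nn2)nc(-c2ccc(C(C)C)cc2)c1C#N` gives 7230 nM; these two sit within the scatter of each other, so no order between them is claimed.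

Two measured steps lead away from compound 1. The exchange of methoxy for chloro gives a 2.1-fold lower number from compound 1 to compound 2 (0.32 log units; beyond the scatter). The exchange of the whole aryl group, 2-methylphenyl in place of 4-chlorophenyl, gives a 1.5-fold lower number from compound 1 to compound 3 (0.19 log units; within the scatter). Between the two replacements themselves, a 1.3-fold higher number from compound 2 to compound 3 (0.13 log units; within the scatter).

Compound 4 `COc1ccccc1Nc1nc(SCc2cn(CC(=O)NC(=O)Nc3ccccn3)nn2)nc(-c2ccc(C(C)C)cc2)c1C#N` is obtained from compound 1 by the change (2-methoxyphenyl in place of 4-chlorophenyl on a nitrogen on an aromatic ring). This change joins features of both measured steps: the methoxy group of compound 2 and the 2-substituted aryl of compound 3. Both steps lowered the number, one modestly and one within the scatter, so a modest fall is expected here as well, and no reversal toward a higher number.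

The expected value for compound 4 is 6200 nM, with a range of 3000 nM to 13000 nM. This expectation corresponds to a step of a 1.8-fold lower number from compound 1 to compound 4 (0.26 log units; within the scatter) for compound 4.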

Compound 4, half-maximal inhibitory concentration: 8960 nM
Estimate against measurement, compound 4: 1.4-fold (0.16 log units) below; low and high end bracket the measured number.
By their numbers in this assay, from the lowest: compounds 2, 3, 4 and 1 (each within the scatter of the next, the first and the last beyond it).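

On a nitrogen on an aromatic ring, 2-methoxyphenyl in place of 4-chlorophenyl gives a 1.3-fold lower number from compound 1 to compound 4 (0.10 log units; within the scatter) in this assay, so this exchange stays within the scatter, whereas the exchange to 4-methoxyphenyl gives a 2.1-fold lower number from compound 1 to compound 2 (0.32 log units; beyond the scatter), which lies beyond it. The two methoxy isomers cannot be told apart, with a 1.7-fold higher number from compound 2 to compound 4 (0.22 log units; within the scatter), and neither can the 2-substituted pair carrying methoxy and methyl on the aromatic carbon, with a 1.2-fold higher number from compound 3 to compound 4 (0.09 log units; within the scatter), so the data show no separate effect of either the methoxy position or the exchange of methoxy for methyl. No measurement at hand bears on the reason for these small differences.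

All four compounds carry a substituted phenyl on this nitrogen and share the rest of the structure, so these numbers say nothing about how other parts of the molecule contribute. On these data alone, it remains open whether a phenyl bearing a dimethylamino group or a carboxylic acid, or a butyl chain in place of the aryl group, would give a number beyond the scatter of the four values seen here.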